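The source may hold more compounds than are shown below. What is called first, only, known or untested is meant among the compounds shown, and "the series" means these compounds.

Measured compounds in a functional assay on HEK293 cells for agonist activity at Bombesin receptor subtype-3 (Homo sapiens), read by luminescence and calcium flux, with a stated time of 10 min; on this read-out lower numbers stand for an effect already at smaller amounts and higher numbers for an effect only at larger amounts of compound:
- compound 1 `CCC(C)(C)Cc1c[nH]c(CCc2ccc(-c3ccncc3)cc2)n1`: 95 nM
- compound 2 `CCC(C)(C)Cc1c[nH]c(CCc2ccc(-n3ccnn3)cc2)n1`: 93 nM
- compound 3 `CCC(C)(C)Cc1c[nH]c(CCc2ccc(-n3cccn3)cc2)n1`: 106 nM

Among these three numbers compound 1 holds the second highest, yet the spread is negligible: a 1.0-fold lower number from compound 1 to compound 2 (0.01 log units; within the scatter), a 1.1-fold higher number from compound 1 to compound 3 (0.05 log units; within the scatter), and a 1.1-fold higher number from compound 2 to compound 3 (0.06 log units; within the scatter). Each of these steps replaces the whole terminal aromatic group that sits on the shared core of compound 1, and none of them moves the read-out beyond the usual scatter.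

The next compound, compound 4 `CCC(C)(C)Cc1c[nH]c(CCc2ccc(-c3ccc(F)cn3)cc2)n1`, makes a change of the same kind at the same place: 5-fluoropyridin-2-yl in place of pyridin-4-yl on an aromatic carbon. The entering group keeps one six-membered aromatic ring with a single hetero atom and one hydrogen-bond acceptor, adding only a fluorine; the group is attached through a different ring carbon than in compound 1.

All three measured steps bear on this change, and all were within the scatter, so no step beyond the scatter is expected here either, in either direction. Within the data shown here, the series so far gives no sign that the identity of the terminal aromatic group matters on this read-out. Compound 4 is therefore expected to show a 1.1-fold higher number from compound 1 to compound 4 (0.02 log units; within the scatter) in this assay. The estimate for compound 4 is 100 nM, with a range from 40 nM to 250 nM.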

Compound 4, half-maximal effective concentration: 97 nM
For compound 4 the middle estimate is 1.0-fold (0.01 log units) above the measured one; measured number inside the range.
By their numbers in this assay, from the lowest: compounds 2, 1, 4 and 3 (each within the scatter of the next).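

Notes on the terminal group, on an aromatic carbon para to a large group, in this assay: the earlier steps exchanged only unsubstituted rings, whereas 5-fluoropyridin-2-yl adds a fluorine and joins through a different ring carbon than pyridin-4-yl, and the read-out still stays within the scatter (a 1.0-fold higher number from compound 1 to compound 4 (0.01 log units; within the scatter)). The comparisons with the two nitrogen-linked groups, 1H-pyrazol-1-yl and 1H-1,2,3-triazol-1-yl, also stay within the scatter (a 1.1-fold lower number from compound 3 to compound 4 (0.04 log units; within the scatter); a 1.0-fold higher number from compound 2 to compound 4 (0.02 log units; within the scatter)), so all the steps among the four compounds remain flat, with none going against this. Nothing available gives a reason for this insensitivity.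

The four groups shown are all aromatic rings, so it remains open whether a carboxylic acid, a primary amine or a longer alkyl chain at this place would also stay within the scatter. Among these compounds, it is equally open whether a second fluorine or a trifluoromethyl on the pyridine ring would leave the read-out as flat as the single fluorine of compound 4 does.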